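The source may hold more compounds than are shown below. What is called first, only, known or untested is meant among the compounds shown, and "the series" means these compounds.

Among the compounds with values here, compound 3, `COc1cccc(CNCCCNc2ccnc3cc(Oc4ccc(Cl)cc4)ccc23)c1O`, sits at the low end of the three numbers so far: in a physicochemical assay for solubility, with a stated time of 18 h, at pH 7.4 (a lower number here means a less soluble compound, a higher number a more soluble compound), compound 3 gives 14500 nM. Compound 1, `COc1ccccc1Oc1ccc2c(NCCCNCc3ccco3)ccnc2c1`, gives 14500 nM in this assay, the same at the digits shown, so the two cannot be told apart. Compound 2, `c1ccc(-c2ccc3c(NCCCNCc4ccco4)ccnc3c2)cc1`, gives 32000 nM in this assay, a step beyond the scatter above both.

Compound 4, `COc1cccc(CNCCCNc2ccnc3cc(-c4ccc(C(F)(F)F)cc4)ccc23)c1O`, differs from compound 3 in one place: 4-(trifluoromethyl)phenyl in place of 4-chlorophenoxy on an aromatic carbon.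

Within the data shown here, only one measured step speaks to a change of this kind. Going from compound 1 to compound 2, a phenyl took the place of a 2-methoxyphenoxy on an aromatic carbon, and in this assay that gave a 2.2-fold higher number from compound 1 to compound 2 (0.34 log units; beyond the scatter). The present change also swaps an aryl ether for a directly attached phenyl, though the group that enters carries a trifluoromethyl rather than nothing, so the earlier step is a guide and not a copy.

The expectation for compound 4 is therefore a rise in this assay of about a 1.5-fold higher number from compound 3 to compound 4 (0.18 log units; within the scatter), a modest step that may or may not clear the scatter. Compound 4 is estimated to give 22000 nM in this assay, with a range from 8000 nM to 50000 nM.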

Compound 4, solubility: 32000 nM
Estimate against measurement, compound 4: 1.5-fold (0.16 log units) below, and the stated range covers the measured number.
By their numbers in this assay, from the lowest: compounds 1 and 3 (each within the scatter of the next); then compounds 2 and 4 (each within the scatter of the next).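

Replacing 4-chlorophenoxy with 4-(trifluoromethyl)phenyl on this aromatic carbon gives, in this assay, a 2.2-fold higher number from compound 3 to compound 4 (0.34 log units; beyond the scatter), so a ring attached directly in place of one attached through an oxygen now goes with a higher number in a second pair of compounds. The earlier pair gave a 2.2-fold higher number from compound 1 to compound 2 (0.34 log units; beyond the scatter), a step of the same printed size, even though those two compounds carry a different chain on the core and their entering group is a plain phenyl, without the trifluoromethyl. Two pairs are still only two pairs, and nothing shown here explains why the number moves with this change.

Both steps remove the linking oxygen and alter the groups on the outer ring at the same time, so the compounds shown do not separate the loss of that oxygen from the change of ring substituent; a 4-chlorophenyl group at this position, which keeps the chlorine and drops only the oxygen, would pull the two apart. Also open, on these data alone, is how this position behaves with a group of a different kind, such as a morpholine ring or a carboxylic acid, in place of an outer carbon ring.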